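Lengthening a Glycol Chain on a Hindered Ester

The compounds below may be only part of what the source reports. "The series", "measured", "known", "first", "only" and "open" are said of these compounds alone.

Compound 1, `COCCOCCOCCOCCOCCOCCOCC(=O)Oc1c(C(C)C)cccc1C(C)C`, gives 520000 nM in an ADME assay on A549 cells (Homo sapiens) for cytotoxicity, read by MTT assay, with a stated time of 24 h; a lower number here means that less compound is needed, a higher number that more compound is needed for the effect.
Compound 2, `COCCOCCOCC(=O)Oc1c(C(C)C)cccc1C(C)C`, gives 4150000 nM in this assay.

Compound 1 holds the lowest of the two numbers; its nearest neighbour is compound 2, with an 8.0-fold higher number from compound 1 to compound 2 (0.90 log units; beyond the scatter). Compound 3, `COCCOCCOCCOCCOCCOCCOCCOCCOCCOCCOCC(=O)Oc1c(C(C)C)cccc1C(C)C`, differs from compound 1 by a group of 12 heavy atoms (8 carbon, 4 oxygen; no ring) in place of a hydrogen atom, on a saturated chain carbon bound to an oxygen on a saturated carbon. Within the data shown here, the only step that bears on this is the one from compound 1 to compound 2, where removing a group of the same kind raised the number well beyond the scatter; adding one more such group is expected to lower it, though probably by less. Compound 3 is therefore expected at 200000 nM, between 80000 nM and 500000 nM, a step of a 2.6-fold lower number from compound 1 to compound 3 (0.41 log units; beyond the scatter).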

Compound 3, half-maximal effective concentration: 600000 nM
Compound 3: middle estimate off by 3.0-fold (0.48 log units), on the low side; the whole stated range lies below it.
By their numbers in this assay, from the lowest: compounds 1 and 3 (each within the scatter of the next); then compound 2.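

On this saturated chain carbon, adding the group of 12 heavy atoms (8 carbon, 4 oxygen; no ring) gives a 1.2-fold higher number from compound 1 to compound 3 (0.06 log units; within the scatter) in this assay and so does not move the number measurably. Removing a group of the same kind gave an 8.0-fold higher number from compound 1 to compound 2 (0.90 log units; beyond the scatter) and did move it, so among these compounds the effect of chain length is not steady. Nothing shown accounts for this levelling off.

Still open, as far as these compounds go, is whether a chain ending in an amine or a carboxylic acid would follow the same course. An even longer chain could also stay level or move the number again.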